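Thiophene in place of bromine on compound 3

A few compounds are considered here, and "the series" means these few. Any claim that something is new, unique, unknown or untested is made for them only; others in the source may bear on it.

Measured in a functional assay on CHO cells for antagonist activity at C-X-C chemokine receptor type 3 (Homo sapiens), read by GTPgammaS binding; a lower number here means a stronger inhibitor, a higher number a weaker inhibitor:
compound 1 `CC(=O)c1cccc(NC(=O)NC2CCN(CC3=CC[C@H]4C[C@@H]3C4(C)C)CC2)c1` gives 258 nM
compound 2 `CC1(C)[C@H]2CC=C(CN3CCC(NC(=O)Nc4cc(F)cc(F)c4)CC3)[C@@H]1C2` gives 171 nM
compound 3 `CC1(C)[C@H]2CC=C(CN3CCC(NC(=O)Nc4cncc(Br)c4)CC3)[C@@H]1C2` gives 171 nM

Compound 3 stands level with compound 2 at the digits printed, the two together the lowest of the three numbers; its furthest neighbour is compound 1, and the step of a 1.5-fold lower number from compound 1 to compound 3 (0.18 log units; within the scatter) is within the scatter. Compound 4 `CC1(C)[C@H]2CC=C(CN3CCC(NC(=O)Nc4cncc(-c5cccs5)c4)CC3)[C@@H]1C2` differs from compound 3 by thiophen-2-yl in place of bromo on an aromatic carbon. For the measured compounds named here, the steps that bear on changes at this aryl group, a 1.5-fold lower number from compound 1 to compound 2 (0.18 log units; within the scatter) and no change at the digits printed from compound 2 to compound 3 (within the scatter), both stayed within the scatter, so no step beyond the scatter in this assay is expected, though none of the measured steps exchanges a halogen for a ring. The estimate for compound 4 is therefore a 1.3-fold lower number from compound 3 to compound 4 (0.12 log units; within the scatter). Compound 4 is expected to give 130 nM, in the range 30 nM to 550 nM.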

Compound 4, inhibition constant: 70 nM
Estimate against measurement, compound 4: 1.9-fold (0.27 log units) above; measured number inside the range.
By their numbers in this assay, from the lowest: compound 4; then compounds 2, 3 and 1 (each within the scatter of the next).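

In this assay, for the compounds shown here, this is the first change at the aryl group to step beyond the scatter: thiophen-2-yl in place of bromo gives a 2.4-fold lower number from compound 3 to compound 4 (0.39 log units; beyond the scatter), whereas the exchanges among compound 1, compound 2 and compound 3 did not separate them. This aromatic carbon therefore accepts a five-membered aromatic ring of 5 heavy atoms in place of a single bromine without loss, and the number falls modestly. Nothing measured here explains the step. From the compounds shown here alone, whether a phenyl, furan-2-yl or thiophen-3-yl group on this carbon would give a similar step remains open. So does the effect of an amine or a carboxylic acid there.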